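Oxime ether series: ester to acid on the oxime oxygen

This account rests on a few compounds, and the source may have more. Where it says the series, first, only, none or still open, it means among the compounds named here.

Compound 2 `CCOC(=O)CO/N=C(/c1ccc(OC)c(OC)c1OC)c1cccc2ccccc12` carries the ethyl ester oxime ether on the shared core, which compound 1 `COc1ccc(/C(=N/O)c2cccc3ccccc23)c(OC)c1OC` bears as the free oxime. In a functional assay on THP-1 cells (Homo sapiens) for inhibition, read by sulforhodamine B assay, with a stated time of 48 h (a higher number here means a weaker inhibitor, a lower number a stronger inhibitor), compound 2 gives only a limit, > 20000 nM. Compound 1 likewise gives a limit in this assay, > 20000 nM. Compound 3 `COc1ccc(/C(=C/c2ccc(F)cc2)c2cccc3ccccc23)c(OC)c1OC`, the alkene analogue, gives 18900 nM in this assay. The step that the two limits leave unreadable from compound 1 to compound 2 cannot be read, as both of its values fall at the limit of > 20000 nM in this assay, at which 2 of the 3 values shown sit. Compound 4 `COc1ccc(/C(=N/OCC(=O)O)c2cccc3ccccc23)c(OC)c1OC` differs from compound 2 by hydrogen in place of ethyl on an oxygen next to a carbonyl group. Within the data shown here, no measured step bears on this change, and two of the three values in this assay are limits. Compound 4 is therefore expected to remain near the limit, with an expected step that the limit leaves unreadable from compound 2 to compound 4. The estimate for compound 4 is 25000 nM, ranging from 10000 nM to 60000 nM.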

Compound 4, half-maximal inhibitory concentration: > 20000 nM
Compound 4: a limit, no number (the forecaster's own chance of this, stated with the estimate: 80%); the middle value does not contradict the limit.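

Among these compounds, compound 4 gives only a limit in this assay, so no step from compound 1 or compound 2 to compound 4 can be read: the limit of > 20000 nM in this assay, at which 3 of the 4 values shown sit.

In this assay the compounds shown leave open whether ethoxycarbonyl to carboxy changes inhibition at all.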